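The source may report more compounds than this note shows. Statements on the series, on what has been measured and on what is new or still open speak of the compounds shown alone.

Of the compounds shown here, two have been measured so far in an assay for inhibition of RAC-alpha serine/threonine-protein kinase (Homo sapiens), read by HTRF, with a stated time of 1 h; a lower number here means a stronger inhibitor, a higher number a weaker inhibitor. Compound 1 `CNC(=O)C[C@@H]1C[C@@H](c2ccc(Cl)c(Cl)c2)[C@H](NC(=O)c2cc(-c3c(Cl)cnn3C)c(Cl)o2)CN1` gives 2.64 nM, the lower of the two numbers and so the stronger inhibitor of the pair. Compound 2 `Cn1ncc(Cl)c1-c1cc(C(=O)NC2CNCC2c2ccc(C(F)(F)F)cc2)oc1Cl`, built around the same core but differing in several places at once, gives 538 nM, a far higher number that lies well beyond the scatter of repeated measurements. Within the data shown here, since no single-point step between these two exists, nothing more than this comparison of values can be drawn from them.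

Compound 3 `C=CC[C@@H]1C[C@@H](c2ccc(Cl)c(Cl)c2)[C@H](NC(=O)c2cc(-c3c(Cl)cnn3C)c(Cl)o2)CN1` has not yet been measured. It differs from compound 1 in a single place: vinyl in place of methylcarbamoyl on a saturated chain carbon bound to a saturated ring carbon. The group that leaves carries one hydrogen-bond donor and one hydrogen-bond acceptor, the group that enters carries none. On that basis, compound 1 to compound 3 is expected to show a modest step toward weaker inhibition, a 4.5-fold higher number from compound 1 to compound 3 (0.66 log units; beyond the scatter). For compound 3 the estimated value is 12 nM, with a likely range from 3 nM to 50 nM.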

Compound 3, half-maximal inhibitory concentration: 12.4 nM
Compound 3: middle estimate off by 1.0-fold (0.01 log units), on the low side, and the stated range covers the measured number.
By their numbers in this assay, from the lowest: compound 1; then compound 3; then compound 2.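

In this assay, putting vinyl in place of methylcarbamoyl on a saturated chain carbon bound to a saturated ring carbon gives a 4.7-fold higher number from compound 1 to compound 3 (0.67 log units; beyond the scatter) as a modest step. Among these compounds, this is the first single-place comparison, and it shows that this position still allows strong inhibition with a group that has no hydrogen-bond donors or acceptors: compound 3 stays at 12.4 nM and remains far below the number for compound 2, which differs from it in several places. No measurement shown here explains the size of this step.

The change swaps the amide for a smaller hydrocarbon group, so the effect of removing the amide cannot be separated from the effect of size. An amine, a carboxylic acid or a longer chain at this position would help to tell how far this tolerance extends.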